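A few compounds are considered here, and "the series" means these few. Any claim that something is new, unique, unknown or untested is made for them only; others in the source may bear on it.

Measured compounds:
compound 1, `C=C1C[C@]23C[C@@]1(O)CC[C@H]2c1cc2c(C(=O)O)coc2c(C)c1[C@@H]3C(=O)O`, > 10000 nM
compound 2, `C=C1C[C@]23C[C@@]1(O)CC[C@H]2[C@@]12C=C[C@H](O)[C@@](C)(C(=O)O1)[C@H]2[C@@H]3C(=O)OC`, > 10000 nM

Both compounds were tested in an ADME assay on HEK-293T cells (Homo sapiens) for cytotoxicity, read by luminescence and CellTiter-Glo, with a stated time of 24 h; on this read-out higher numbers stand for weaker inhibition and lower numbers for stronger inhibition. In this assay compound 1 gives > 10000 nM, which is a limit of the assay rather than a number. Compound 2 likewise gives > 10000 nM in this assay, again a limit and not a number. Compound 2 therefore stands at the limit of > 10000 nM in this assay, at which 2 of the 2 values shown sit, and nothing in the values shown separates it from compound 1, since neither was pinned down to a number. For the measured compounds named here, no step between measured compounds can be read off here.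

Compound 3, `C=C1[C@@H](O)[C@]23C[C@@]1(O)CC[C@H]2[C@@]12C=C[C@H](O)[C@@](C)(C(=O)O1)[C@H]2[C@@H]3C(=O)OC`, has not yet been tested in this assay. It differs from compound 2 in one place: hydroxy in place of hydrogen on a saturated ring carbon.

With both measured values resting at the limit, the expected step that the limit leaves unreadable from compound 2 to compound 3 is none beyond the scatter, and compound 3 is most likely to return the same limit. On that basis compound 3 is estimated at 15000 nM in this assay, with a range from 5000 nM to 50000 nM.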

Compound 3, half-maximal inhibitory concentration: > 10000 nM
Compound 3 was reported as a limit; the forecaster's own chance of this, stated with the estimate: 85%; the middle value is on the limit's open side.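

Compound 2 and compound 3 both rest at a limit of the assay rather than at a number, so no step between them can be read: the limit of > 10000 nM in this assay, at which 3 of the 3 values shown sit.

The compounds shown leave open how strongly any of them acts in this assay, and whether hydroxy in place of hydrogen on a saturated ring carbon changes that at all.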